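The source may report more compounds than this note shows. Statements on the series, on what has been measured and on what is new or still open speak of the compounds shown alone.

Measured so far in a functional assay on PC-3 cells (Homo sapiens) for antiproliferative activity, read by MTT assay, with a stated time of 48 h; on this read-out lower numbers stand for stronger inhibition and higher numbers for weaker inhibition:
compound 1 `CCn1c(C(=O)Nc2ccc(OC(F)(F)F)cc2)ccc1C(CC)(CC)c1ccc(OCCC(O)(CC)CC)c(C)c1` — > 50000 nM
compound 2 `CCOc1ccc(NC(=O)c2ccc(C(CC)(CC)c3ccc(OCCC(O)(CC)CC)c(C)c3)n2CC)cc1` — > 50000 nM

Compound 1, `CCn1c(C(=O)Nc2ccc(OC(F)(F)F)cc2)ccc1C(CC)(CC)c1ccc(OCCC(O)(CC)CC)c(C)c1`, reached only a limit of the assay: in this assay compound 1 gives > 50000 nM, which is a limit and not a number. Compound 2, `CCOc1ccc(NC(=O)c2ccc(C(CC)(CC)c3ccc(OCCC(O)(CC)CC)c(C)c3)n2CC)cc1`, stands at the same place: in this assay compound 2 gives > 50000 nM, again a limit rather than a measured value. For the measured compounds named here, the one step between them, a step that the two limits leave unreadable from compound 1 to compound 2, therefore cannot be read, since both ends sit at the limit of > 50000 nM in this assay, at which 2 of the 2 values shown sit.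

Compound 3, `CCn1c(C(=O)N(C)CC(=O)O)ccc1C(CC)(CC)c1ccc(OCCC(O)(CC)CC)c(C)c1`, is not yet measured. It differs from compound 2 in one place: (carboxymethyl)(methyl)amino in place of (4-ethoxyphenyl)amino on a carbonyl carbon. No measured step touches this part of the molecule; the only step shown, that from compound 1 to compound 2, concerns the group on the oxygen of the aromatic ring at the other end and is unreadable in size. With both measured values sitting at the limit, there is no direction or size to carry over, and the expectation for compound 3 rests on that alone. Compound 3 is accordingly expected to give about 80000 nM in this assay, within 20000 nM to 300000 nM, most likely again reported only as a limit, which would mean a step that the limit leaves unreadable from compound 2 to compound 3 that is itself unreadable.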

Compound 3, half-maximal inhibitory concentration: 2250 nM
Compound 3: the middle estimate sits 36-fold (1.55 log units) above what was measured; measured number outside the range, below it.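

In this assay, (carboxymethyl)(methyl)amino in place of (4-ethoxyphenyl)amino on the carbonyl carbon gives an at least 22-fold lower number from compound 2 to compound 3 (1.34 log units; beyond the scatter). The same group in place of (4-(trifluoromethoxy)phenyl)amino gives an at least 22-fold lower number from compound 1 to compound 3 (1.34 log units; beyond the scatter), so at this position the change produces a large step from either of the two earlier compounds, whereas the earlier change, on the group at the oxygen of the aromatic ring, could not be read. The substituent on the carbonyl carbon is thus the first place in these compounds where a change brings the read-out to a measured number, and compound 3 is the only one of the three that gives such a number rather than a limit: the limit of > 50000 nM in this assay, at which 2 of the 3 values shown sit.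

The change removes the six-membered aromatic ring and brings in the carboxymethyl group and the methyl on the nitrogen all at once, so the compounds shown do not tell which of these parts accounts for the step. As far as these compounds go, it remains open whether the number would hold with a methyl ester in place of the carboxylic acid, with the amide hydrogen in place of the methyl on the nitrogen, or with a longer chain carrying the carboxylic acid.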